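This account rests on a few compounds, and the source may have more. Where it says the series, first, only, none or still open, it means among the compounds named here.

Measured compounds in an ADME assay on MT4 cells (Homo sapiens) for cytotoxicity, read by MTT assay; on this read-out higher numbers stand for lower toxicity in this test and lower numbers for higher toxicity in this test:
compound 1 `Cc1c(N)nc(Nc2ccc(C#N)cc2)nc1Cc1c(F)cccc1F`: 45900 nM
compound 2 `Cc1c(N)nc(Nc2ccc(C#N)cc2)nc1C(C)c1c(F)cccc1F`: 40500 nM

Compound 1 holds the highest of the two numbers in this assay; its nearest neighbour is compound 2, and the step of a 1.1-fold lower number from compound 1 to compound 2 (0.05 log units; within the scatter) lies within the scatter, so the two compounds read alike on this test.

Compound 3 `Cc1cnc(Nc2ccc(C#N)cc2)nc1Cc1c(F)cccc1F` has not yet been measured in this assay. It differs from compound 1 in one place: hydrogen in place of amino on an aromatic carbon. Among the compounds with values here, the only measured step, a 1.1-fold lower number from compound 1 to compound 2 (0.05 log units; within the scatter), concerns a different site, the saturated chain carbon bound to two aromatic carbons, and so bears on the present change only in a general way: it shows that one small alteration of the shared core left the read-out essentially unchanged. Within the data shown here, no measured pair speaks directly to the removal of amino from the aromatic carbon. Among the measured compounds shown here, with no direct precedent, no step beyond the scatter is expected in this assay. The estimate for compound 3 is 42000 nM, with a range from 18000 nM to 95000 nM. The step this implies, a 1.1-fold lower number from compound 1 to compound 3 (0.04 log units; within the scatter), is expected to remain within the scatter, the broad range reflecting the absence of a comparable measured change.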

Compound 3, half-maximal cytotoxic concentration: > 74300 nM
Compound 3 was reported as a limit (the forecaster's own chance of this, stated with the estimate: 10%); at least 1.7-fold (0.24 log units) between middle value and limit.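

In this assay compound 3 is reported only as a limit, > 74300 nM, and not as a number. Within the data shown here, this is the first measured change on this aromatic carbon of the shared core, and replacing amino with hydrogen gives an at least 1.6-fold higher number from compound 1 to compound 3 (0.20 log units; that floor lies within the scatter), so this position loses its amino group without any lower number on this read-out, while the true size of the step is not fixed beyond that floor. The top of the measurable range now constrains what can be read at this position: the limit of > 74300 nM in this assay, at which 1 of the 3 values shown sits.

From the compounds shown here alone, whether the step truly exceeds the scatter remains open, as does whether the methyl on the saturated chain carbon of compound 2 would read the same once the amino group is gone. Also open, going by these compounds, is how a methoxy or dimethylamino group on this same aromatic carbon would read, and so whether any group there, rather than amino specifically, would shift the number in this test.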